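Swapping Methoxy for Chloro on a Cytotoxic Core

The compounds below may be only part of what the source reports. "The series", "measured", "known", "first", "only" and "open" are said of these compounds alone.

The compounds share one core, seen first in compound 1 `NS(=O)(=O)c1ccc(Nc2nc3nc(=O)[nH]c(-c4ccccc4)c3s2)cc1`. In a functional assay on Caco-2 cells (Homo sapiens) for cytotoxicity, read by MTT assay, with a stated time of 24 h (on this read-out lower numbers stand for stronger inhibition and higher numbers for weaker inhibition), compound 1 gives 334 nM. Compound 2 `COc1ccc(-c2[nH]c(=O)nc3nc(Nc4ccc(S(N)(=O)=O)cc4)sc23)cc1` carries a methoxy on an aromatic carbon where compound 1 carries hydrogen; in this assay compound 2 gives 667 nM. Of the two numbers measured, that of compound 2 is the higher, but the step of a 2.0-fold higher number from compound 1 to compound 2 (0.30 log units; within the scatter) is within the scatter, so the two compounds cannot be told apart on these data.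

Compound 3 `NS(=O)(=O)c1ccc(Nc2nc3nc(=O)[nH]c(-c4ccc(Cl)cc4)c3s2)cc1` is not yet measured. It differs from compound 2 by chloro in place of methoxy on an aromatic carbon. For the measured compounds named here, no measured step involves a chloro group, so the only guide is the single measured step of a 2.0-fold higher number from compound 1 to compound 2 (0.30 log units; within the scatter), which shows that a change at this aromatic carbon left the number essentially where it was. On that basis the step to compound 3 is expected to be a 1.5-fold lower number from compound 2 to compound 3 (0.17 log units; within the scatter), within the scatter. The estimate for compound 3 in this assay is 450 nM, with a range from 200 nM to 1100 nM.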

Compound 3, half-maximal inhibitory concentration: 12700 nM
For compound 3 the middle estimate is 28-fold (1.45 log units) below the measured one, and the stated range ends below it.
By their numbers in this assay, from the lowest: compounds 1 and 2 (each within the scatter of the next); then compound 3.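

The carbon para to a large group turns out not to be indifferent to what it carries: in this assay hydrogen and methoxy could not be told apart there, yet chloro gives a 19-fold higher number from compound 2 to compound 3 (1.28 log units; beyond the scatter) and, set against hydrogen, a 38-fold higher number from compound 1 to compound 3 (1.58 log units; beyond the scatter) on the same carbon. Since a higher number stands for weaker inhibition here, compound 3 is the weakest of the three, with both of its steps beyond the scatter, so a small difference between two groups at this carbon does not predict what a third group will do. Nothing at hand accounts for this loss, so the data record its size and give no explanation.

For the compounds shown here, with only one chloro compound, it remains open whether the loss belongs to chloro alone or would also appear with another group on this carbon, such as fluoro, methyl or an amine. From the compounds shown here alone, it is equally open whether chloro at another carbon of the same ring would give a similar number, or whether this carbon is the only one that matters.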